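The source may hold more compounds than are shown below. What is called first, only, known or untested is meant among the compounds shown, and "the series" means these compounds.

Compound 1 `COc1cccc(CNC(=O)c2nn(C)c3cc(-c4cn[nH]c4)ccc23)c1` and compound 2 `COc1cccc(CNC(=O)c2n[nH]c3cc(-c4cn[nH]c4)ccc23)c1` share one core and differ only in that compound 2 carries hydrogen in place of methyl on an aromatic nitrogen. In an assay on isolated protein for inhibition of Rho-associated protein kinase 2 (Homo sapiens), read by HTRF, with a stated time of 4 h (on this read-out lower numbers stand for stronger inhibition and higher numbers for weaker inhibition), compound 1 gives < 1 nM, which is a limit of the assay rather than a number. In this assay compound 2 also gives < 1 nM, again a limit. Because both sit at the limit of < 1 nM in this assay, at which 2 of the 3 values shown sit, the step that the two limits leave unreadable from compound 1 to compound 2 cannot be sized. Compound 3 `COc1cccc(CNC(=O)c2nc3ccc(-c4cn[nH]c4)cc3[nH]2)c1`, built on a different core, gives 4 nM in this assay. Compound 4 `COc1cccc(CN(C(=O)c2n[nH]c3cc(-c4cn[nH]c4)ccc23)C2CC2)c1` is compound 2 with cyclopropyl in place of hydrogen on an amide-type nitrogen. Within the data shown here, no measured step touches an amide-type nitrogen, so no measured step bears on this change, and compound 2 itself is known only as a limit. Compound 4 is expected to be weaker by an at least 10-fold higher number from compound 2 to compound 4 (1.00 log units; beyond the scatter). The estimate for compound 4 is 10 nM, from 1 nM to 100 nM.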

Compound 4, half-maximal inhibitory concentration: 6 nM
Compound 4: middle estimate off by 1.7-fold (0.22 log units), on the high side; low and high end bracket the measured number.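

Among these compounds, this is the first measured change on an amide-type nitrogen, and in this assay cyclopropyl in place of hydrogen there gives an at least 6.0-fold higher number from compound 2 to compound 4 (0.77 log units; beyond the scatter). Compound 4 shows that this nitrogen can carry cyclopropyl and still give a value of 6 nM, so the amide hydrogen is not essential for strong inhibition. The true step may be larger, because the number for compound 2 is only a limit: the limit of < 1 nM in this assay, at which 2 of the 4 values shown sit.

The compounds shown leave open how a methyl or a longer chain on this nitrogen would compare with cyclopropyl. They also cannot separate the loss of the hydrogen from the arrival of the cyclopropyl.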